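Methoxy in place of hydrogen on compound 3

The source may hold more compounds than are shown below. What is called first, only, known or untested is meant among the compounds shown, and "the series" means these compounds.

Measured so far in an ADME assay on J774.A1 cells (Mus musculus) for cytotoxicity, read by MTT assay, with a stated time of 48 h; a lower number here means that less compound is tolerated, a higher number that more compound is tolerated
compound 1 `COC(=O)c1c(NCc2ccc(OC)cc2)noc1-c1ccc([N+](=O)[O-])cc1` gives "not determined" (no result reported)
compound 2 `COC(=O)c1c(NCc2ccc(OC)c(OC)c2)noc1-c1ccc([N+](=O)[O-])cc1` gives "not determined" (no result reported)
compound 3 `COC(=O)c1c(NCc2ccc(OC)cc2)noc1-c1ccc(Cl)cc1Cl` gives 34700 nM

For the measured compounds named here, compound 3 carries the only number, as compound 1 and compound 2 have no result. Nothing therefore places it high or low within the series. The next compound is compound 4 (`COC(=O)c1c(NCc2ccc(OC)c(OC)c2)noc1-c1ccc(Cl)cc1Cl`), which has methoxy in place of hydrogen on an aromatic carbon. Going by the values given here, no measured pair shows this change in this assay, so no step beyond the scatter is expected, in either direction. The expected step is a 1.1-fold lower number from compound 3 to compound 4 (0.04 log units; within the scatter) and rests only on compound 3 at 34700 nM as the anchor. For compound 4 the estimated value is 32000 nM (14000 nM to 70000 nM).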

Compound 4, half-maximal cytotoxic concentration: 7580 nM
Beside the measured number, compound 4's estimate is 4.2-fold (0.63 log units) above it, and the stated range ends above it.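

In this assay, for the compounds shown here, the step of a 4.6-fold lower number from compound 3 to compound 4 (0.66 log units; beyond the scatter) is the first readable one, and it comes from methoxy in place of hydrogen on an aromatic carbon, ortho to a methoxy group. This position therefore responds to the change, with less compound tolerated once the second methoxy is present. Nothing available accounts for the size of the step.

On these data alone, the finding rests on this single pair, so it remains open whether the same change behaves alike on other compounds. As far as these compounds go, it also remains open whether a hydroxyl, an ethoxy or an amine at this place would give a similar step.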